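The source may report more compounds than this note shows. Statements on the series, on what has been measured and on what is new or still open speak of the compounds shown alone.

Three ureas built on a shared core have been measured in a functional assay on A-375 cells (Homo sapiens) for inhibition, read by MTT assay, with a stated time of 120 h; a higher number here means a weaker inhibitor, a lower number a stronger inhibitor. Compound 1 `CC(NC(=O)c1cccc(-c2ccc(NC(=O)Nc3ccc(Cl)c(C(F)(F)F)c3)cc2)c1)c1ccccc1` gives 5170 nM, the lowest of the two numbers shown. Compound 3 `CC(NC(=O)/C=C/c1ccc(NC(=O)Nc2cc(C(F)(F)F)ccc2Cl)cc1)c1ccccc1` gives 40900 nM, a gap from compound 1 that lies beyond the scatter. Compound 2 `CC1CN(C(=O)/C=C/c2ccc(NC(=O)Nc3ccc(Cl)c(C(F)(F)F)c3)cc2)CC(C)O1` returns > 50000 nM, which is a limit of the assay and not a number. This is the limit of > 50000 nM in this assay, at which 1 of the 3 values shown sits.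

The unmeasured compound 4 `CNC(=O)c1cccc(-c2ccc(NC(=O)Nc3ccc(Cl)c(C(F)(F)F)c3)cc2)c1` differs from compound 1 in one place: methyl in place of 1-phenylethyl on an amide-type nitrogen. Among the compounds with values here, no measured pair shows this change, and the values of compound 1 and compound 3 concern a different part of the molecule, so they give no direct guide. A weaker result than compound 1 is expected, with the step of a 2.9-fold higher number from compound 1 to compound 4 (0.46 log units; beyond the scatter), though the scatter of such measurements leaves room for no change at all. In this assay compound 4 is therefore estimated at 15000 nM, with a likely range from 4000 nM to 50000 nM.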

Compound 4, half-maximal inhibitory concentration: 46500 nM
Estimate against measurement, compound 4: 3.1-fold (0.49 log units) below, and the stated range covers the measured number.
By their numbers in this assay, from the lowest: compound 1; then compounds 3 and 4 (each within the scatter of the next). At a limit, above all of these: compound 2.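

In this assay the amide-type nitrogen proves to be a position where a single change registers: methyl in place of 1-phenylethyl gives a 9.0-fold higher number from compound 1 to compound 4 (0.95 log units; beyond the scatter). Within the data shown here, this is the first measured step at this place, since the earlier compounds offered no pair differing here, and it shows that compound 1 holds its lower number only with the 1-phenylethyl group in place. Nothing measured among these compounds gives a cause for the step.

On these data alone, with only these two groups at this nitrogen, it remains open whether the aromatic ring or the branched carbon chain accounts for the gap. A benzyl group, a cyclohexyl ring, or a longer chain ending in an amine or a carboxylic acid on the same nitrogen would bear on that question.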